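Dichlorophenyl to dimethylphenyl: working notes on the next step

The compounds below may be only part of what the source reports. "The series", "measured", "known", "first", "only" and "open" are said of these compounds alone.

Measured so far in a functional assay (aorta) with Rattus norvegicus as the target (on this read-out lower numbers stand for stronger inhibition and higher numbers for weaker inhibition), as follows
- compound 1 `CC1(C)Oc2ccc(C#N)cc2[C@@H](/N=C(\NC#N)Oc2ccccc2)[C@@H]1O` gives > 100000 nM (a limit)
- compound 2 `CC1(C)Oc2ccc(C#N)cc2[C@@H](/N=C(\NC#N)Nc2ccc(Cl)c(Cl)c2)[C@@H]1O` gives 4600 nM

The entry for compound 1, > 100000 nM (a limit), is not a number. Going by the values given here, compound 2, at 4600 nM in this series, therefore holds the only true number so far.

Among the compounds with values here, the one measured step, an at least 21-fold lower number from compound 1 to compound 2 (1.33 log units; beyond the scatter), is large and puts (3,4-dichlorophenyl)amino in place of phenoxy on a carbon with a double bond to nitrogen. Compound 3 `Cc1ccc(N/C(=N/[C@@H]2c3cc(C#N)ccc3OC(C)(C)[C@H]2O)NC#N)cc1C` keeps the amine nitrogen and changes only the group on it, with 3,4-dimethylphenyl in place of 3,4-dichlorophenyl on an amine nitrogen.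

Within the data shown here, the step to compound 2 bears on this only indirectly: it shows that this assay can respond strongly to a change on that carbon, but no measured pair compares two groups on the amine nitrogen. A smaller shift than an at least 21-fold lower number from compound 1 to compound 2 (1.33 log units; beyond the scatter) is therefore expected, tentatively towards a higher number. The expected size is a 1.7-fold higher number from compound 2 to compound 3 (0.24 log units; within the scatter), which may not clear the scatter. Compound 3 is estimated at 8000 nM, with an expected range from 2000 nM to 30000 nM.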

Compound 3, half-maximal inhibitory concentration: 5100 nM
Beside the measured number, compound 3's estimate is 1.6-fold (0.20 log units) above it; the range from low to high includes it.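

In this assay, going by these compounds alone, the first comparison of two groups on the amine nitrogen gives a 1.1-fold higher number from compound 2 to compound 3 (0.04 log units; within the scatter), so 3,4-dimethylphenyl and 3,4-dichlorophenyl cannot be told apart here, and replacing chlorine with carbon in these two ring substituents has no readable effect on this read-out. The large step away from phenoxy now appears with a second aryl group, an at least 19-fold lower number from compound 1 to compound 3 (1.29 log units; beyond the scatter), so within these compounds it does not depend on the chlorine atoms of compound 2. The size of that step remains open-ended, since the entry for compound 1 is a limit and not a number: the limit of > 100000 nM in this assay, at which 1 of the 3 values shown sits.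

The phenoxy and amine compounds also differ in their ring substituents, so a plain phenylamino group would be needed to separate the effect of the amine nitrogen from that of the two ring substituents. The compounds shown also leave open how far this flat response on the amine nitrogen extends, for example to a benzyl group, a naphthyl group or a simple alkyl chain such as butyl.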